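Trading a sulfonyl group for a sulfanyl group

The compounds below may be only part of what the source reports. "The series", "measured", "known", "first", "only" and "open" are said of these compounds alone.

Among the compounds with values here, in a functional assay on DU-145 cells (Homo sapiens) for inhibition, read by trypan blue exclusion, with a stated time of 96 h (on this read-out higher numbers stand for weaker inhibition of growth and lower numbers for stronger inhibition of growth), compound 3 (`O=C(O)c1ccc(C(=O)/C(=C\c2ccc(Cl)c([N+](=O)[O-])c2)S(=O)(=O)Cc2ccc(Br)cc2)cc1`) gives 25000 nM as the highest of the three numbers so far. Compound 1 (`O=C(O)c1ccc(C(=O)/C(=C\c2ccc(Cl)c([N+](=O)[O-])c2)SCc2ccc(Cl)cc2)cc1`) stands at 1000 nM and compound 2 (`O=C(O)c1ccc(C(=O)/C(=C\c2ccc(Cl)c([N+](=O)[O-])c2)SCc2ccccc2F)cc1`) at 1000 nM on the same scale. Compound 4 (`Cc1ccc(CS/C(=C/c2ccc(Cl)c([N+](=O)[O-])c2)C(=O)c2ccc(C(=O)O)cc2)cc1`) is still unmeasured. The change from compound 3 to compound 4 puts (4-methylbenzyl)sulfanyl in place of (4-bromobenzyl)sulfonyl on a double-bonded chain carbon bound to a carbonyl carbon and a double-bonded chain carbon.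

Two large steps bear on this, each running from a sulfanyl to a sulfonyl group, with a 25-fold higher number from compound 1 to compound 3 (1.40 log units; beyond the scatter) and a 25-fold higher number from compound 2 to compound 3 (1.40 log units; beyond the scatter) in the same direction. In both, the group on the ring changes along with the group on sulfur, so the two changes are not separated. Between the two sulfanyl compounds there is no change at the digits printed from compound 1 to compound 2 (within the scatter) despite a different ring group. Within the data shown here, no measurement yet covers (4-methylbenzyl)sulfanyl itself. Compound 4 is therefore expected to sit with the sulfanyl compounds, and the estimate means a 25-fold lower number from compound 3 to compound 4 (1.40 log units; beyond the scatter) as a large move towards stronger inhibition. For compound 4 the estimated value is 1000 nM with an expected range from 400 nM to 3000 nM in this estimate.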

Compound 4, concentration for 50% growth inhibition: 1000 nM
Compound 4: middle estimate and measured number agree at the digits printed; low and high end bracket the measured number.
By their numbers in this assay, from the lowest: compounds 1, 2 and 4 (each within the scatter of the next); then compound 3.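

In this assay, methyl in place of chloro on an aromatic carbon gives no change at the digits printed from compound 1 to compound 4 (within the scatter), and 4-methylphenyl in place of 2-fluorophenyl on a saturated chain carbon bound to a sulfur gives no change at the digits printed from compound 2 to compound 4 (within the scatter), so the sulfanyl series now holds chloro, fluoro and methyl ring groups with nothing to tell them apart. Within the data shown here, the third step, a 25-fold lower number from compound 3 to compound 4 (1.40 log units; beyond the scatter), again changes the group on the ring and the group on sulfur together, but compound 3, the only sulfonyl compound, is now the only one of the four that stands apart, which makes a ring-group effect less likely to account for the gap without excluding one for bromo. Nothing among the data shown explains why the sulfonyl compound differs from the sulfanyl compounds.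

The compounds shown leave open whether the sulfonyl group alone accounts for the gap, since bromo appears only with sulfonyl and methyl, chloro and fluoro only with sulfanyl. They also leave open how a sulfinyl group would behave at this place, and how an amine or a methoxy group would behave in place of the methyl of compound 4.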